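This account rests on a few compounds, and the source may have more. Where it says the series, first, only, none or still open, it means among the compounds named here.

Three compounds have values in a functional assay on HepG2 cells (Homo sapiens) for cytotoxicity, read by MTT assay, with a stated time of 48 h (a lower number here means a stronger inhibitor, a higher number a weaker inhibitor), so far: compound 1 `COc1cc(/C=C/C(=O)/C=C/c2nc3c(C)c(C)ccc3n2C)ccc1O` gives 8500 nM, compound 2 `COc1ccc(/C=C/C(=O)/C=C/c2nc3cc(C)ccc3n2C)cc1O` gives 3300 nM, and compound 3 `COc1ccc(/C=C/C(=O)/C=C/c2nc3c(C)cccc3n2C)cc1O` gives 14700 nM. Compound 3 lies within the scatter of compound 1, while compound 2 has a lower number than compound 3, beyond the scatter. Compound 4 `COc1ccc(/C=C/C(=O)/C=C/c2nc3c(C)c(C)ccc3n2C)cc1O` differs from compound 3 by methyl in place of hydrogen on an aromatic carbon. Going by the values given here, no measured pair shows this change on its own. The expectation rests on compound 3 at 14700 nM and compound 1 at 8500 nM, and no step beyond the scatter is expected in this assay. The expected change is a 1.5-fold lower number from compound 3 to compound 4 (0.17 log units; within the scatter). For compound 4 the estimate is 10000 nM, with an expected range of 4000 nM to 22000 nM.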

Compound 4, half-maximal inhibitory concentration: 3900 nM
Compound 4: the middle estimate sits 2.6-fold (0.41 log units) above what was measured; measured number outside the range, below it.
By their numbers in this assay, from the lowest: compounds 2 and 4 (each within the scatter of the next); then compounds 1 and 3 (each within the scatter of the next).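

In this assay, methyl in place of hydrogen on the aromatic carbon ortho to a methyl group, meta to a fused ring and para to a fused ring, gives a step beyond the scatter (a 3.8-fold lower number from compound 3 to compound 4 (0.58 log units; beyond the scatter)). Compound 4 stays within the scatter of compound 2 (a 1.2-fold higher number from compound 2 to compound 4 (0.07 log units; within the scatter)), so the high number of compound 3 does not carry over once both methyl groups are present. With both methyl groups in place, 3-hydroxy-4-methoxyphenyl gives a lower number than 4-hydroxy-3-methoxyphenyl (a 2.2-fold lower number from compound 1 to compound 4 (0.34 log units; beyond the scatter)).

As far as these compounds go, whether chlorine or ethyl on this aromatic carbon would behave like methyl remains open. Nothing at hand explains these steps.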